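The compounds below may be only part of what the source reports. "The series", "measured", "known", "first", "only" and "open" are said of these compounds alone.

Measured compounds in a functional assay on HCT-116 cells (Homo sapiens), read by MTT assay, with a stated time of 72 h; on this read-out higher numbers stand for weaker inhibition and lower numbers for stronger inhibition:

- compound 1 `COc1nc(N)nc2c1c(-c1ccco1)cn2[C@@H]1O[C@H](CO)[C@@H](O)[C@H]1O`: > 20000 nM, a limit of the assay
- compound 2 `Nc1nc(N)c2c(-c3cc4ccccc4o3)cn([C@@H]3O[C@H](CO)[C@@H](O)[C@H]3O)c2n1`: 14000 nM
- compound 3 `Nc1nc(N)c2c(-c3ccco3)cn([C@@H]3O[C@H](CO)[C@@H](O)[C@H]3O)c2n1`: > 20000 nM, a limit of the assay

Among the measured compounds shown here, compound 2 carries the only numerical value in this assay; the other two values sit at the limit of > 20000 nM in this assay, at which 2 of the 3 values shown sit. The cores of compound 3 and compound 2 differ by 1-benzofuran-2-yl in place of furan-2-yl on an aromatic carbon, and this gives an at least 1.4-fold higher number from compound 2 to compound 3 (0.15 log units; that floor lies within the scatter).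

The change methoxy in place of amino on an aromatic carbon from compound 3 to compound 1 is a step that the two limits leave unreadable from compound 3 to compound 1. The same change is now made from compound 2 to compound 4 `COc1nc(N)nc2c1c(-c1cc3ccccc3o1)cn2[C@@H]1O[C@H](CO)[C@@H](O)[C@H]1O`: methoxy in place of amino on an aromatic carbon, at a place described in the same words as for compound 1.

Because compound 2 sits at 14000 nM and the step onward is only an at least 1.4-fold higher number from compound 2 to compound 3 (0.15 log units; that floor lies within the scatter), little room remains above that one numerical value. The expected step from compound 2 is a 1.4-fold higher number from compound 2 to compound 4 (0.15 log units; within the scatter). Compound 4 is therefore estimated at 20000 nM in this assay, with a range from 9000 nM to 45000 nM, and a limit rather than a number is a real possibility.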

Compound 4, half-maximal inhibitory concentration: > 20000 nM
Compound 4 gave a limit, no number; the forecaster's own chance of this, stated with the estimate: 55%; the middle value lies on the limit itself.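

In this assay, methoxy in place of amino on an aromatic carbon, opposite the ring nitrogen, gives an at least 1.4-fold higher number from compound 2 to compound 4 (0.15 log units; that floor lies within the scatter), so on this core no change beyond the scatter can be stated. Compound 4 gives > 20000 nM, which is a limit of the assay and not a number. The steps from compound 3 to compound 1 and from compound 1 to compound 4 cannot be read, so the series shows that the change, made on either core, ends at the same limit, but not whether its size carries from one core to the other: the limit of > 20000 nM in this assay, at which 3 of the 4 values shown sit.

Open, as far as these compounds go, is whether an ethoxy or a dimethylamino group at the same place would give a number rather than a limit. Also open, from the compounds shown here alone, is whether a nitrile or a carboxylic acid on the 1-benzofuran-2-yl group would bring the values low enough for the amino-to-methoxy change to be sized on both cores.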